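This account rests on a few compounds, and the source may have more. Where it says the series, first, only, none or still open, it means among the compounds named here.

Measured so far in an ADME assay on GES1 cells (Homo sapiens) for antiproliferative activity, read by MTT assay, with a stated time of 72 h; a lower number here means a stronger inhibitor, a higher number a weaker inhibitor: compound 1 `C/C(=N\Nc1nc(SCc2ccccc2)nc2c1nnn2Cc1ccccc1)c1ccccc1O` gives 56200 nM. Compound 3 `CCCSc1nc(N/N=C(\C)c2ccccc2O)c2nnn(Cc3ccccc3)c2n1` gives 32300 nM. Compound 2 `CCCSc1nc(N/N=C/c2cc(OC)c(OC)c(OC)c2)c2nnn(Cc3ccccc3)c2n1` gives only a limit of the assay, > 64000 nM.

Compound 3 and compound 1 differ by a single change, (phenyl in place of ethyl on a saturated chain carbon bound to a sulfur), which made a 1.7-fold higher number from compound 3 to compound 1 (0.24 log units; within the scatter). The cores of compound 2 and compound 3 differ in more than one place; that difference is not broken down here.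

Compound 4 `COc1cc(/C=N/Nc2nc(SCc3ccccc3)nc3c2nnn3Cc2ccccc2)cc(OC)c1OC` is still to be measured in this assay. It stands to compound 2 as compound 1 stands to compound 3: phenyl in place of ethyl on a saturated chain carbon bound to a sulfur, the same change at the same place. Because compound 2 sits at the limit of > 64000 nM in this assay, at which 1 of the 3 values shown sits, a step that the limit leaves unreadable from compound 2 to compound 4 is expected, as modest as the measured one, resting on the change behaving alike in both pairs. Compound 4 is accordingly expected to give 80000 nM, within 40000 nM to 160000 nM, and most likely to be reported again only as a limit.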

Compound 4, half-maximal inhibitory concentration: 48300 nM
Estimate against measurement, compound 4: 1.7-fold (0.22 log units) above, and the stated range covers the measured number.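

In this assay, the change from propylsulfanyl to benzylsulfanyl gives an at least 1.3-fold lower number from compound 2 to compound 4 (0.12 log units; that floor lies within the scatter). Compound 2 is reported only as a limit of the assay, > 64000 nM. The pairs therefore set the same change on two cores, but they neither show that it carries over alike nor show that it behaves differently: the same change on two cores in this assay, a 1.7-fold higher number (0.24 log units; within the scatter) from compound 3 to compound 1 and an at least 1.3-fold lower number (0.12 log units; that floor lies within the scatter) from compound 2 to compound 4; the limit leaves it open whether they differ

The compounds shown leave open what other groups on the saturated chain carbon bound to the sulfur would do, such as a longer chain, an amine or a carboxylic acid. They also leave open whether the change would read the same on a third core, especially one whose propylsulfanyl member is not at a limit.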